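The compounds below may be only part of what the source reports. "The series", "measured", "known", "first", "only" and "open" are said of these compounds alone.

Compound 1 `N/C(=N\O)c1ccc(C2=C(S(=O)(=O)c3ccc(/C(N)=N/O)cc3)CC(c3ccccc3)(c3ccccc3)O2)cc1` is a compound whose effect on the growth of human immune cells was measured in an ADME assay on THP-1 cells (Homo sapiens) for cytotoxicity, read by flow cytometry, with a stated time of 72 h; a higher number here means a weaker inhibitor, a lower number a stronger inhibitor; here compound 1 gives 119000 nM, the highest of the three numbers recorded so far. Two companions have been measured alongside it. Compound 2 `CC1(c2ccccc2)CC(S(=O)(=O)c2ccc(/C(N)=N/O)cc2)=C(c2ccc(/C(N)=N/O)cc2)O1` gives 99500 nM in this assay, and compound 3 `N/C(=N\O)c1ccc(S(=O)(=O)C2=C(c3ccc(Nc4cccc(/C(N)=N/O)c4)cc3)OC(c3ccccc3)(c3ccccc3)C2)cc1` gives 48100 nM.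

Each of these differs from compound 1 in one place. Going from compound 1 to compound 2 swaps a phenyl for a methyl on a saturated ring carbon, and a 1.2-fold lower number from compound 1 to compound 2 (0.08 log units; within the scatter). Going from compound 1 to compound 3 replaces a small group by a larger one that carries an aromatic ring, and a 2.5-fold lower number from compound 1 to compound 3 (0.39 log units; beyond the scatter).

Compound 4 `N/C(=N\O)c1ccc(C2=C(S(=O)(=O)c3ccc(Nc4ccccc4/C(N)=N/O)cc3)CC(c3ccccc3)(c3ccccc3)O2)cc1` is the next compound to be tested. Compared with compound 1, the change is a group of 11 heavy atoms (7 carbon, 3 nitrogen, 1 oxygen; one six-membered aromatic ring of carbon only) in place of a group of 4 heavy atoms (1 carbon, 2 nitrogen, 1 oxygen; no ring), on an aromatic carbon. Going by the values given here, this is the same kind of replacement as the one from compound 1 to compound 3, carried out on the other side of the shared core, so that step is the only guide available. On that basis a modest lowering of the number is expected, a 2.2-fold lower number from compound 1 to compound 4 (0.34 log units; beyond the scatter). Compound 4 is therefore estimated to give 55000 nM in this assay, with a plausible range from 25000 nM to 120000 nM.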

Compound 4, half-maximal inhibitory concentration: > 50000 nM
Compound 4 was reported as a limit; the forecaster's own chance of this, stated with the estimate: 10%; the middle value is on the limit's open side.
By their numbers in this assay, from the lowest: compound 3; then compounds 2 and 1 (each within the scatter of the next).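

In this assay compound 4 gives > 50000 nM, which is a limit of the assay and not a number. The step between compound 1 and compound 4 cannot be read, so no size can be given for it. The compounds shown leave open whether the group of 11 heavy atoms lowers the number in compound 4, as it does in compound 3.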